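A methyl dropped from compound 2: what to expect

This account rests on a few compounds, and the source may have more. Where it says the series, first, only, none or still open, it means among the compounds named here.

Compound 1 `Cc1cc(O)cc(-c2nn(CC#N)cc2-c2ccnc(-c3ccc(Oc4ccccc4)cc3)c2)c1` in a functional assay on UACC-62 cells (Homo sapiens) for cytotoxicity, read by sulforhodamine B assay, with a stated time of 48 h, tested at 0.001 uM (on this read-out higher numbers stand for a weaker effect at the one concentration tested and lower numbers for a stronger effect), gives 92%.
Compound 2 `COc1cc(C)cc(-c2nn(CC#N)cc2-c2ccnc(-c3ccc(N(C)C)cc3)c2)c1` in this assay gives 91%.

Compound 2 and compound 1 sit within the usual scatter of each other in this assay, so neither can be told apart from the other on the numbers shown. Compound 3 `Cc1cc(O)cc(-c2nn(CC#N)cc2-c2ccnc(-c3ccc(N(C)C)cc3)c2)c1` is not yet measured. It differs from compound 2 in one place: hydrogen in place of methyl on an oxygen on an aromatic ring. Going by the values given here, no pair of measured compounds shows what such a change does here, so the step from compound 2 to compound 3 is expected to be a number 1 percentage points lower from compound 2 to compound 3 (within the scatter), nothing beyond the scatter. Compound 3 is therefore estimated at 90%, expected between 80% and 98%.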

Compound 3, a percentage reported as activity, at one concentration (the size of the read-out at that concentration, not a potency): 90%
Compound 3: the middle estimate sits on the measured number at the digits printed; low and high end bracket the measured number.
By their numbers in this assay, from the lowest: compounds 3, 2 and 1 (each within the scatter of the next).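

Replacing methoxy with hydroxy on the aromatic ring gives no readable change in this assay: the step is a number 1 percentage points lower from compound 2 to compound 3 (within the scatter). Dimethylamino in place of phenoxy on an aromatic carbon likewise gives a number 2 percentage points lower from compound 1 to compound 3 (within the scatter), so at the one concentration tested neither change separates the compounds. No measurement at hand offers an explanation for either step.

As far as these compounds go, what a longer chain such as ethyl on that oxygen would do remains open. So does the effect of an amine or a carboxylic acid in place of the dimethylamino group.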